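A few compounds are considered here, and "the series" means these few. Any claim that something is new, unique, unknown or untested is made for them only; others in the source may bear on it.

Compound 1 `O=C(CCn1cnc2cc(-c3noc(CCC4CCCC4)n3)ccc21)N1CCOCC1`: > 20000 nM
Compound 2 `O=C(CCn1cnc2cc(-c3noc(CCC4CCCC4)n3)ccc21)NC1CCCC1`: > 20000 nM

In a toxicity assay on HepG2 2.2.15 cells (Homo sapiens) for cytotoxicity, read by CCK-8 assay, with a stated time of 72 h (a lower number here means that less compound is tolerated, a higher number that more compound is tolerated), compound 1 reaches only the limit of the measurement, > 20000 nM. Compound 2 likewise reaches only a limit, > 20000 nM. Both values sit at the same limit (the limit of > 20000 nM in this assay, at which 2 of the 2 values shown sit), so the step that the two limits leave unreadable from compound 1 to compound 2 cannot be read as a number. For the measured compounds named here, compound 2 therefore stands at the edge of what this assay can report: there is no measured value of its own and no measured step leading to it.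

Compound 3 `Cc1ccccc1NC(=O)CCn1cnc2cc(-c3noc(CCC4CCCC4)n3)ccc21` differs from compound 2 by a single change: 2-methylphenyl in place of cyclopentyl on an amide-type nitrogen. Going by the values given here, no measured step bears directly on this exchange, and the one step that was measured, from a morpholin-4-yl to a cyclopentylamino group, stays hidden behind the limit. The expectation for compound 3 in this assay rests on both measured compounds sitting at the limit. The expected step that the limit leaves unreadable from compound 2 to compound 3 is therefore none beyond the scatter. In this assay compound 3 is expected at 25000 nM, with a range from 10000 nM to 80000 nM, most likely again reported only as a limit.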

Compound 3, half-maximal cytotoxic concentration: > 20000 nM
Compound 3: no number, only a limit (the forecaster's own chance of this, stated with the estimate: 80%); the middle value lies beyond the limit too.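

In this assay compound 3 gives > 20000 nM, which is a limit and not a number. The steps among compound 1, compound 2 and compound 3 therefore cannot be read: the limit of > 20000 nM in this assay, at which 3 of the 3 values shown sit. The compounds shown leave open how much of each compound these cells actually tolerate, and whether changing the group on the carbonyl carbon alters that at all.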